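Two Aryl Swaps on an Aromatic Nitrogen of One Core

The source may report more compounds than this note shows. Statements on the series, on what has been measured and on what is new or still open speak of the compounds shown alone.

Measured compounds:
Compound 1, `C[C@H](Nc1ncnc2[nH]cnc12)c1nn(-c2cccnc2)c2cc(F)ccc12`: 20%
Compound 2, `C[C@H](Nc1ncnc2[nH]cnc12)c1nn(-c2cccc(S(C)(=O)=O)c2)c2cc(F)ccc12`: 11%

Among the measured compounds shown here, compound 2 holds the lower of the two numbers in a functional assay on Hep 3B2 cells (Homo sapiens) for inhibition, read by sulforhodamine B assay, with a stated time of 72 h, tested at 10 uM (on this read-out higher numbers stand for more inhibition at the one concentration tested (going by the name of the read-out) and lower numbers for less inhibition), with compound 1 its only neighbour, and the step of a number 9 percentage points lower from compound 1 to compound 2 (within the scatter) lies within the scatter. Compound 3, `C[C@H](Nc1ncnc2[nH]cnc12)c1nn(-c2ccccn2)c2cc(F)ccc12`, has not been measured in this assay. It differs from compound 2 in one place: pyridin-2-yl in place of 3-(methylsulfonyl)phenyl on an aromatic nitrogen. For the measured compounds named here, the one measured step that bears on this change is the earlier swap at the same aromatic nitrogen, a number 9 percentage points lower from compound 1 to compound 2 (within the scatter), which stayed within the scatter; the group entering compound 3 is an isomer of the group that compound 1 carries at that nitrogen. Both measured values are low, so no step beyond the scatter is expected. Compound 3 is therefore expected to give about 15%, within a range of 0% to 35%. The expected step of a number 4 percentage points higher from compound 2 to compound 3 (within the scatter) is judged small.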

Compound 3, a percentage reported as inhibition, at one concentration (the size of the read-out at that concentration, not a potency): 12%
For compound 3 the middle estimate is 3 percentage points above the measured one; the range from low to high includes it.
By their numbers in this assay, from the lowest: compounds 2, 3 and 1 (each within the scatter of the next).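

At the aromatic nitrogen of the shared core, this assay gives a number 1 percentage points higher from compound 2 to compound 3 (within the scatter) for the exchange of 3-(methylsulfonyl)phenyl, a group of 10 heavy atoms, for pyridin-2-yl, a group of 6. The comparison of the two pyridine isomers, new with this compound, gives a number 8 percentage points lower from compound 1 to compound 3 (within the scatter), so neither exchange separates the compounds beyond the scatter. Nothing given here explains these numbers.

On these data alone, all three groups at this nitrogen are six-membered aromatic rings, so it remains open whether a non-aromatic group there, such as a methyl group or a longer alkyl chain, would give a step beyond the scatter. As far as these compounds go, it also remains open whether an amine or a carboxylic acid on the aromatic ring would do so.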